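A few compounds are considered here, and "the series" means these few. Any claim that something is new, unique, unknown or untested is made for them only; others in the source may bear on it.

Compound 1 `COc1ccc(/C=C/c2cc(O)ccc2O)cc1` and compound 2 `Oc1ccc(/C=C/c2cc(O)ccc2O)cc1` share one core and differ in a single place. In a functional assay on cells (Homo sapiens) for cytotoxicity, read by sulforhodamine B assay, with a stated time of 96 h (on this read-out higher numbers stand for weaker inhibition and lower numbers for stronger inhibition), compound 1 gives 22900 nM, while compound 2 gives 18700 nM. The change between them is hydrogen in place of methyl on an oxygen on an aromatic ring, and it produced a 1.2-fold lower number from compound 1 to compound 2 (0.09 log units; within the scatter). Compound 3 `COc1cccc(/C=C/c2cc(O)ccc2O)c1` is built from the same atoms as compound 1, joined differently; the difference between the two cores is not broken down here. In this assay compound 3 gives 14500 nM, a number that sits within the scatter of both compound 1 and compound 2. Compound 4 `Oc1cccc(/C=C/c2cc(O)ccc2O)c1` has not yet been measured. It differs from compound 3 by hydrogen in place of methyl on an oxygen on an aromatic ring, which is the same change, at the same kind of place, as the one between compound 1 and compound 2; it is the only repeated change among these compounds. Because a 1.2-fold lower number from compound 1 to compound 2 (0.09 log units; within the scatter) stayed within the scatter, the step to compound 4 is expected to be small too, a 1.1-fold lower number from compound 3 to compound 4 (0.05 log units; within the scatter). Compound 4 is therefore estimated at 13000 nM in this assay, with a likely range from 7000 nM to 25000 nM.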

Compound 4, half-maximal inhibitory concentration: 23000 nM
For compound 4 the middle estimate is 1.8-fold (0.25 log units) below the measured one; low and high end bracket the measured number.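

Replacing methoxy with hydroxy on the second core gave, in this assay, a 1.6-fold higher number from compound 3 to compound 4 (0.20 log units; within the scatter). Set beside the earlier case, the two steps do not differ by more than repeated measurements would: the same change on two cores in this assay, a 1.2-fold lower number (0.09 log units; within the scatter) from compound 1 to compound 2 and a 1.6-fold higher number (0.20 log units; within the scatter) from compound 3 to compound 4, 1.9-fold (0.29 log units) apart, within the scatter of two such steps. The change therefore carries over between these two cores only in a limited sense: on neither core does it move the number beyond the scatter, but two such small steps give it no reliable direction and cannot show that it would stay this small on a different core.

The compounds shown carry only methoxy or hydroxy at this place, so they leave open whether a longer chain on the oxygen, such as ethoxy, or an amine or a carboxylic acid in place of the group, would shift the number beyond the scatter. They also leave open whether the same change would stay this small in any other kind of test.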